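This account rests on a few compounds, and the source may have more. Where it says the series, first, only, none or still open, it means among the compounds named here.

Two closely related compounds have been measured in an assay on isolated protein for inhibition of Apoptosis regulator Bcl-2 (Homo sapiens), read by fluorescence polarization, with stated times of 5 min and 10 min; on this read-out higher numbers stand for weaker inhibition and lower numbers for stronger inhibition. Compound 1 `CC(C)=CCCC1=CC[C@H](C(=O)N(C)O)[C@@H](c2ccccc2)C1` carries a methyl on the amide nitrogen and a free hydroxyl on the oxygen; in this assay compound 1 gives 2100 nM. Compound 2 `CONC(=O)[C@@H]1CC=C(CCC=C(C)C)C[C@H]1c1ccccc1` reverses that arrangement, with a hydrogen on the nitrogen and a methyl on the oxygen; in this assay compound 2 gives 2700 nM. Of the two numbers shown, that of compound 2 is the higher, but the gap to compound 1 lies within the usual scatter of repeated measurements, so the two results cannot be told apart with confidence.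

Compound 3 `CC(C)=CCCC1=CC[C@@H](C(=O)NO)[C@H](c2ccccc2)C1` has not yet been measured. It differs from compound 2 by a single change, (hydrogen in place of methyl on an oxygen), leaving a free hydroxamic acid in which both the nitrogen and the oxygen carry hydrogen. Among the compounds with values here, no measured pair in this set isolates this particular change, so the direction of the step cannot be read from the data. The expected step from compound 2 to compound 3 is small, a 1.4-fold lower number from compound 2 to compound 3 (0.13 log units; within the scatter), and may well fall within the scatter. Compound 3 is therefore estimated at 2000 nM, with a plausible range from 700 nM to 6000 nM.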

Compound 3, inhibition constant: 700 nM
Beside the measured number, compound 3's estimate is 2.9-fold (0.46 log units) above it; the measured number falls inside the stated range.
By their numbers in this assay, from the lowest: compound 3; then compounds 1 and 2 (each within the scatter of the next).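

In this assay, replacing the methyl on the oxygen with a hydrogen turns the methoxycarbamoyl group of compound 2 into the hydroxycarbamoyl group of compound 3, and this gives a 3.9-fold lower number from compound 2 to compound 3 (0.59 log units; beyond the scatter). The step is modest, but it shows that this oxygen is a place where the loss of a single carbon atom can be seen clearly in the read-out, with the rest of the molecule unchanged. No supporting measurement in hand explains why the number falls.

The compounds shown give only two end points at this oxygen, hydrogen and methyl, so it remains open whether an ethyl group or a longer chain there would sit near compound 2 or go further still. From the compounds shown here alone, it also remains open whether the hydroxycarbamoyl group is needed in full, or whether a carboxylic acid or a primary amide in its place would keep the lower number seen with compound 3.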